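This account rests on a few compounds, and the source may have more. Where it says the series, first, only, none or still open, it means among the compounds named here.

Within the data shown here, in a functional assay on HCT-116 cells (Homo sapiens) for cytotoxicity, read by resazurin assay, with a stated time of 48 h (a higher number here means that more compound is needed for the effect, a lower number that less compound is needed), three compounds have numbers so far. Compound 1 (`COc1ccc(S(=O)(=O)Nc2ccc3oc(-c4ccc(NC(=O)c5cccc(C)c5[N+](=O)[O-])cc4)nc3c2)cc1`) gives 4400 nM, the lowest of the three. Compound 2 (`O=C(Nc1ccc(Sc2nc3ccccc3s2)c(Cl)c1)c1cccc(Br)c1O`) gives 12000 nM and compound 3 (`Nc1ccc(S(=O)(=O)Nc2ccc(-c3nc4cc(NS(=O)(=O)c5ccc(N)cc5)ccc4o3)cc2)cc1`) gives 17000 nM, each beyond the scatter from compound 1. Compound 4 (`COc1ccc(S(=O)(=O)Nc2ccc3oc(-c4ccc(NC(=O)C5CCN(C(C)=O)CC5)cc4)nc3c2)cc1`) keeps the core of compound 1 and differs in the group on a carbonyl carbon whose other neighbour is an amide-type nitrogen: 1-acetylpiperidin-4-yl in place of 3-methyl-2-nitrophenyl on a carbonyl carbon. Among the measured compounds shown here, no measured pair shows what a single change does in this assay, so any forecast is loose. A moderate rise beyond the scatter is expected, since compound 1 stands lowest at 4400 nM. The expected step is a 2.3-fold higher number from compound 1 to compound 4 (0.36 log units; beyond the scatter). For compound 4 the estimate is 10000 nM, within an expected range of 3500 nM to 30000 nM.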

Compound 4, half-maximal effective concentration: 15000 nM
For compound 4 the middle estimate is 1.5-fold (0.18 log units) below the measured one; low and high end bracket the measured number.
By their numbers in this assay, from the lowest: compound 1; then compounds 2, 4 and 3 (each within the scatter of the next).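

In this assay, among these compounds, this is the first single change that can be read: on a carbonyl carbon whose other neighbour is an amide-type nitrogen, 1-acetylpiperidin-4-yl in place of 3-methyl-2-nitrophenyl gives a 3.4-fold higher number from compound 1 to compound 4 (0.53 log units; beyond the scatter). The number at this position thus responds to the group placed there, and on the core of compound 1 this exchange moves it upward. No measurement at hand explains the step.

The whole group changes at once, so the shares of the ring, the nitro group and the acetyl group remain unseparated. A plain phenyl or an unsubstituted piperidin-4-yl at this position would be the open comparisons.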